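The compounds below may be only part of what the source reports. "The series", "measured", "known", "first", "only" and "open" are said of these compounds alone.

Compound 1 `C[C@@H]1CCCN1c1c(C#N)c2c(N)nc(Nc3cn[nH]c3)nc2n1C`: 6 nM
Compound 2 `C[C@@H]1CCCN1c1c(C#N)c2c(N)ncnc2n1C`: 15 nM
Compound 3 `Cc1c(Nc2nc(N)c3c(C#N)c(N4CCC[C@H]4C)n(C)c3n2)cnn1C1COC1`: 47 nM

Among the three compounds measured in an assay on isolated protein for inhibition of Leucine-rich repeat serine/threonine-protein kinase 2 (Homo sapiens), read by TR-FRET and LanthaScreen, with stated times of 50 min and 30 min, in the presence of a further agent that is not named here (on this read-out higher numbers stand for weaker inhibition and lower numbers for stronger inhibition), compound 3 gives the highest number, standing a 7.8-fold higher number from compound 1 to compound 3 (0.89 log units; beyond the scatter) and, against compound 2, a gap well beyond the usual scatter. Compound 4 `C[C@@H]1CCCN1c1c(C#N)c2c(N)nc(N)nc2n1C` has not yet been measured; it differs from compound 3 by hydrogen in place of 5-methyl-1-(oxetan-3-yl)-1H-pyrazol-4-yl on a nitrogen on an aromatic ring, so that a plain amino group is left on the shared core.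

Within the data shown here, two measured steps bear on this. The step of a 7.8-fold higher number from compound 1 to compound 3 (0.89 log units; beyond the scatter) shows that adding the 5-methyl and oxetan-3-yl groups to the 1H-pyrazol-4-yl weakens inhibition, so removing that whole group could recover part of the loss. The step of a 2.5-fold higher number from compound 1 to compound 2 (0.40 log units; beyond the scatter) shows that taking the entire (1H-pyrazol-4-yl)amino off costs only a modest amount, placing a bare amine plausibly between compound 1 and compound 2. Compound 4 is therefore expected to show a step of a 3.1-fold lower number from compound 3 to compound 4 (0.50 log units; beyond the scatter), toward stronger inhibition. The estimate for compound 4 in this assay is 15 nM, within a range of 5 nM to 50 nM.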

Compound 4, half-maximal inhibitory concentration: 248 nM
Estimate against measurement, compound 4: 17-fold (1.22 log units) below; measured number outside the range, above it.
By their numbers in this assay, from the lowest: compound 1; then compound 2; then compound 3; then compound 4.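

The plain amino group turns out to be a poor choice at this place: putting it on the aromatic carbon of compound 2 gives a 17-fold higher number from compound 2 to compound 4 (1.22 log units; beyond the scatter) and leaves the amine well behind the bare hydrogen. What sits on this nitrogen clearly matters, as losing the 1H-pyrazol-4-yl gives a 41-fold higher number from compound 1 to compound 4 (1.62 log units; beyond the scatter) and even the weaker 5-methyl-1-(oxetan-3-yl)-1H-pyrazol-4-yl is worth keeping, with its loss giving a 5.3-fold higher number from compound 3 to compound 4 (0.72 log units; beyond the scatter) in the direction of weaker inhibition. Nothing measured here explains why the amine falls so far behind.

The compounds shown leave open whether a single methyl or an acetyl on this nitrogen would win back any of the lost inhibition. They also do not tell whether a phenyl ring could take the place of the 1H-pyrazol-4-yl.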